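A few compounds are considered here, and "the series" means these few. Any claim that something is new, unique, unknown or untested is made for them only; others in the source may bear on it.

Measured so far in a functional assay on THP-1 cells (Homo sapiens) for inhibition, read by sulforhodamine B assay, with a stated time of 48 h, tested at 50 uM; a higher number here means more inhibition of growth at the concentration tested, a lower number less inhibition of growth:
- compound 1 `COc1ccccc1/C=C/C(=O)/C=C/c1ccc(OCc2cn(CCCOc3cc(=O)oc4ccccc34)nn2)c(OC)c1`: 50%
- compound 2 `COc1cc(/C=C/C(=O)/C=C/c2ccccc2)ccc1OCc1cn(CCCOc2cc(=O)oc3ccccc23)nn1`: 48%
- compound 3 `COc1cc(/C=C/C(=O)/C=C/c2cc(OC)c(OC)c(OC)c2)ccc1OCc1cn(CCCOc2cc(=O)oc3ccccc23)nn1`: 79%

Compound 3 stands highest of the three, with both gaps beyond the scatter. Next is compound 4 `COc1cc(/C=C/C(=O)/C=C/c2cccs2)ccc1OCc1cn(CCCOc2cc(=O)oc3ccccc23)nn1`, with the change thiophen-2-yl in place of 3,4,5-trimethoxyphenyl on a double-bonded chain carbon bound to a double-bonded chain carbon. Two measured steps at this place bear on it, a number 31 percentage points higher from compound 2 to compound 3 (beyond the scatter) and a number 29 percentage points higher from compound 1 to compound 3 (beyond the scatter). In both, 3,4,5-trimethoxyphenyl enters, whereas here it leaves. The remaining step, a number 2 percentage points lower from compound 1 to compound 2 (within the scatter), separates nothing. Among the measured compounds shown here, no thiophen-2-yl compound has been measured, so a fall of similar size in this assay is only an expectation. The expected step is a number 27 percentage points lower from compound 3 to compound 4 (beyond the scatter). For compound 4 the estimate is 52%, with an expected range of 38% to 68%.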

Compound 4, percent growth inhibition at one concentration: 54%
Compound 4: middle estimate off by 2 percentage points, on the low side; low and high end bracket the measured number.
By their numbers in this assay, from the lowest: compounds 2, 1 and 4 (each within the scatter of the next); then compound 3.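

In this assay, the change at this position works in both directions: removing 3,4,5-trimethoxyphenyl in favour of thiophen-2-yl gives a number 25 percentage points lower from compound 3 to compound 4 (beyond the scatter). The five-membered sulfur ring does not separate from the other two groups, with a number 6 percentage points higher from compound 2 to compound 4 (within the scatter) and a number 4 percentage points higher from compound 1 to compound 4 (within the scatter), so of the four groups only 3,4,5-trimethoxyphenyl stands apart. No measured property accounts for this difference.

From the compounds shown here alone, whether that rise needs every methoxy group of 3,4,5-trimethoxyphenyl remains open. Also open, going by these compounds, is how a pyridine ring or a dimethylaminophenyl group would read on this chain carbon.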